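Replacing diethylamino: from compound 3 to compound 4

The source may hold more compounds than are shown below. What is called first, only, known or untested is meant among the compounds shown, and "the series" means these compounds.

Compound 1 `NC(=O)NC/C=C\CN(C[C@H]1Cc2ncccc2CN1)[C@H]1CCCc2cccnc21`: 10%
Compound 2 `NC(=O)NC/C=C/CN(C[C@H]1Cc2ncccc2CN1)[C@H]1CCCc2cccnc21`: 19%
Compound 3 `CCN(CC)CCCCN(C[C@H]1Cc2ncccc2CN1)[C@H]1CCCc2cccnc21`: 1%

All three values come from an ADME assay on microsomes from liver (Mus musculus) for metabolic stability, using NADPH, with a stated time of 10 min; a higher number here means that more of the compound is left, a lower number that less of the compound is left. Compound 3, at 1%, lies within the scatter of compound 1 and clearly under compound 2. The measured steps are a number 9 percentage points lower from compound 1 to compound 3 (within the scatter) and a number 18 percentage points lower from compound 2 to compound 3 (beyond the scatter).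

The next structure is compound 4 `c1cnc2c(c1)CN[C@@H](CN(CCCCN(C1COC1)C1COC1)[C@H]1CCCc3cccnc31)C2`, and the change is a group of 9 heavy atoms (6 carbon, 1 nitrogen, 2 oxygen; 2 four-membered non-aromatic rings with 1 hetero atom each) in place of a group of 5 heavy atoms (4 carbon, 1 nitrogen; no ring), on a saturated chain carbon, four bonds along the chain from an amine nitrogen. Diethylamino leaves, and the entering group carries 2 four-membered non-aromatic rings with 1 hetero atom each.

Within the data shown here, no measured step changes this group alone. The nearest guides are the two steps above, which also alter the chain end on the shared core: one stays within the scatter and the other is modest. The remaining step, a number 9 percentage points higher from compound 1 to compound 2 (within the scatter), has no bearing here, given (the fact that compounds 1 and 2 differ only in the configuration as drawn).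

A modest upward move is therefore expected in this assay, though a result within the scatter of compound 3 would fit the same evidence. The expected step is a number 11 percentage points higher from compound 3 to compound 4 (beyond the scatter). For compound 4 the estimated value is 12%, with an expected range of 2% to 35%.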

Compound 4, percent of the compound remaining: 33%
The estimate for compound 4 lay 21 percentage points below the measured number; the measured number falls inside the stated range.
By their numbers in this assay, from the lowest: compounds 3, 1 and 2 (each within the scatter of the next, the first and the last beyond it); then compound 4.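

With a number 32 percentage points higher from compound 3 to compound 4 (beyond the scatter) in this assay, the exchange of diethylamino for the group with 2 four-membered non-aromatic rings with 1 hetero atom each gives the only large step shown in the series. The earlier steps shown here that alter the chain end on the shared core stayed within the scatter or were modest, so this result shows that the number can move much further at this place, on a saturated chain carbon, four bonds along the chain from an amine nitrogen, while the chain itself stays unchanged. Nothing in the available evidence bears on the reason for this step.

Open, going by these compounds, is whether the rise needs both four-membered rings: a dimethylamino end, a morpholine, or an amine carrying one such ring and one ethyl group would separate these cases. Also open, on these data alone, is how the same entering group behaves on a shorter or longer chain, or on the unsaturated chain that carries the urea end in compound 1 and compound 2.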